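The compounds below may be only part of what the source reports. "The series", "measured", "known", "first", "only" and "open" are said of these compounds alone.

Compound 1 `O=C1/C(=C/c2ccccc2F)COC/C1=C\c1ccc(Cl)cc1Cl`: 7900 nM
Compound 2 `O=C1/C(=C/c2ccccc2F)COC/C1=C\c1ccccc1Br`: 6500 nM

In a functional assay on A549 cells (Homo sapiens) for cytotoxicity, read by MTT assay, with a stated time of 72 h (a higher number here means a weaker inhibitor, a lower number a stronger inhibitor), compound 2 gives 6500 nM, which lies within the scatter of compound 1 at 7900 nM. Compound 3 `COc1ccccc1/C=C1\COC/C(=C\c2ccccc2F)C1=O` has not yet been measured and carries one change from compound 2: methoxy in place of bromo on an aromatic carbon. Going by the values given here, only one measured step bears on it, a 1.2-fold lower number from compound 1 to compound 2 (0.08 log units; within the scatter), which also altered this substituted phenyl group. Methoxy itself remains untested, so no step beyond the scatter is expected in this assay, and no direction can be favoured. The expected change is a 1.2-fold higher number from compound 2 to compound 3 (0.06 log units; within the scatter). The estimated value for compound 3 is 7500 nM, with an expected range from 2800 nM to 20000 nM.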

Compound 3, half-maximal inhibitory concentration: 5900 nM
Beside the measured number, compound 3's estimate is 1.3-fold (0.10 log units) above it; the range from low to high includes it.
By their numbers in this assay, from the lowest: compounds 3, 2 and 1 (each within the scatter of the next).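

Exchanging bromo, with no hydrogen-bond acceptor, for methoxy, with one, on this aromatic carbon ortho to a large group does not separate the two compounds in this assay, with a 1.1-fold lower number from compound 2 to compound 3 (0.04 log units; within the scatter) as the step. The wider exchange of 2,4-dichlorophenyl for 2-methoxyphenyl also stays inside the scatter, with a 1.3-fold lower number from compound 1 to compound 3 (0.13 log units; within the scatter) as its step. No evidence is available to explain these results.
On these data alone, whether an amine, a carboxylic acid or a longer chain on this aromatic carbon would give a step beyond the scatter remains open. So does the effect of any change to the shared core.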